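The source may hold more compounds than are shown below. What is called first, only, known or untested is meant among the compounds shown, and "the series" means these compounds.

Compound 1, `COc1ccc2c(c1)/C(=N/NC(=S)N1CCN(c3ccccc3)CC1)C(=O)N2`, is tested in a functional assay on MCF7 cells (Homo sapiens) for inhibition, read by MTT assay, with a stated time of 72 h (a higher number here means a weaker inhibitor, a lower number a stronger inhibitor), where compound 1 gives 14400 nM. Two relatives carry other groups on the same ring of the shared core: compound 2, `O=C1Nc2c(Br)cc(Br)cc2/C1=N/NC(=S)N1CCN(c2ccccc2)CC1`, gives 11600 nM, and compound 3, `O=C1Nc2ccc(Cl)cc2/C1=N/NC(=S)N1CCN(c2ccccc2)CC1`, gives 10400 nM; all three numbers lie within the usual scatter of one another. The step of a 1.4-fold lower number from compound 1 to compound 3 (0.14 log units; within the scatter) shows that exchanging the group at this carbon barely moved the number. Compound 4, `O=C1Nc2ccc([N+](=O)[O-])cc2/C1=N/NC(=S)N1CCN(c2ccccc2)CC1`, differs from compound 1 by nitro in place of methoxy on an aromatic carbon. Only the chloro step bears on this change, and it stayed within the scatter, so a step of similar size is expected here, with the number for compound 4 expected to move a 1.3-fold lower number from compound 1 to compound 4 (0.12 log units; within the scatter). Compound 4 is therefore estimated at 11000 nM, likely between 4500 nM and 27000 nM.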

Compound 4, half-maximal inhibitory concentration: 23300 nM
Compound 4: the middle estimate sits 2.1-fold (0.33 log units) below what was measured; low and high end bracket the measured number.
By their numbers in this assay, from the lowest: compounds 3, 2, 1 and 4 (each within the scatter of the next, the first and the last beyond it).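

Replacing methoxy with nitro gives a 1.6-fold higher number from compound 1 to compound 4 (0.21 log units; within the scatter), so a second, different group at this carbon also stays close to compound 1. For the compounds shown here, what is new is that the replacements can be told apart: the nitro and chloro compounds differ by a 2.2-fold higher number from compound 3 to compound 4 (0.35 log units; beyond the scatter), the only step at this carbon that passes the scatter, and only modestly. From the compounds shown here alone, whether an amine or a carboxylic acid here would move the number further from compound 1 stays open. Nothing available explains the gap between nitro and chloro.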